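Chloro for Fluoro in a Cytotoxicity Series

The compounds below may be only part of what the source reports. "The series", "measured", "known", "first", "only" and "open" are said of these compounds alone.

Compound 1 `O=C(O)c1cn(C2CC2)c2c(F)c(N3CCCC3)c(F)cc2c1=O`: 120 ug/mL
Compound 2 `O=C(O)c1cn(C2CC2)c2c(Cl)c(N3CCCC3)c(F)cc2c1=O`: 150 ug/mL
Compound 3 `Nc1c(F)c(N2CCC(N)C2)c(F)c2c1c(=O)c(C(=O)O)cn2C1CC1`: 15 ug/mL

These three compounds were measured in a functional assay on V79 cells (Cricetulus griseus) for cytotoxicity, read by colony formation; a higher number here means a weaker inhibitor, a lower number a stronger inhibitor. Compound 1 and compound 2 differ by a single change, (chloro in place of fluoro on an aromatic carbon), and the step of a 1.3-fold higher number from compound 1 to compound 2 (0.10 log units; within the scatter). Compound 3 stands lowest of the three; the difference between its core and the core of compound 1 is not broken down here.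

Compound 4 `Nc1c(F)c(N2CCC(N)C2)c(Cl)c2c1c(=O)c(C(=O)O)cn2C1CC1` has not been measured. It differs from compound 3 by chloro in place of fluoro on an aromatic carbon. This is the same kind of change as that from compound 1 to compound 2, but the surroundings differ: in compound 3 the carbon is ortho to a 3-aminopyrrolidin-1-yl group and para to an amino group, whereas in compound 1 it is ortho to a pyrrolidin-1-yl group.

Because the step of a 1.3-fold higher number from compound 1 to compound 2 (0.10 log units; within the scatter) stayed within the scatter, the step of a 1.2-fold higher number from compound 3 to compound 4 (0.08 log units; within the scatter) is expected to be small as well. Compound 4 is therefore estimated at 18 ug/mL, with an expected range from 8 ug/mL to 40 ug/mL.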

Compound 4, half-maximal inhibitory concentration: 59 ug/mL
Beside the measured number, compound 4's estimate is 3.3-fold (0.52 log units) below it, and the stated range ends below it.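

In this assay, chloro in place of fluoro on an aromatic carbon gave a 3.9-fold higher number from compound 3 to compound 4 (0.59 log units; beyond the scatter), a step that can be read as a real change on this core. Set beside the earlier step, the size of this change did not carry from one core to the other: the same change on two cores in this assay, a 1.3-fold higher number (0.10 log units; within the scatter) from compound 1 to compound 2 and a 3.9-fold higher number (0.59 log units; beyond the scatter) from compound 3 to compound 4, 3.1-fold (0.50 log units) apart, beyond the scatter of two such steps. These two pairs do not show which of the differences between the cores, the amino group or the 3-aminopyrrolidin-1-yl group in place of the pyrrolidin-1-yl group, goes with the larger step, and they give no basis for predicting the step on any further core.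

The compounds shown leave open whether the larger step would persist with only one of those two groups present on the core. They also leave open how a bromo or a methoxy group on the same aromatic carbon would compare with chloro and fluoro in this assay.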